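Swapping the pyridine for a pyridazine: expected stability

A few compounds are considered here, and "the series" means these few. Any claim that something is new, unique, unknown or untested is made for them only; others in the source may bear on it.

Measured so far:
- compound 1 `FC(F)(F)c1cccc(-c2nc3cnc(Nc4ccccn4)cc3[nH]2)c1`: 45%
- compound 2 `FC(F)(F)c1cccc(-c2nc3cnc(Nc4ccncn4)cc3[nH]2)c1`: 88%

Two compounds share a core and differ only in the aromatic ring attached to the amine nitrogen. For the measured compounds named here, in an ADME assay on microsomes from liver (Rattus norvegicus) for metabolic stability, read by LC-MS, with a stated time of 30 min, tested at 0.1 uM (a higher number here means that more of the compound is left, a lower number that less of the compound is left), compound 1 gives 45%, the lower of the two numbers; its only neighbour, compound 2, gives 88% in this assay, and the step of a number 43 percentage points higher from compound 1 to compound 2 (beyond the scatter) lies beyond the scatter.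

Compound 3 `FC(F)(F)c1cccc(-c2nc3cnc(Nc4cccnn4)cc3[nH]2)c1` has not yet been measured. It differs from compound 1 in one place: pyridazin-3-yl in place of pyridin-2-yl on a nitrogen on an aromatic ring. Going by the values given here, the only measured step that bears on this change is the one from compound 1 to compound 2, which also replaces pyridin-2-yl with a different six-membered aromatic ring carrying nitrogen, and that step was large and upward. Among the compounds with values here, on that basis the change to pyridazin-3-yl is expected to move the number in this assay upward as well, though with less confidence, since only one such step is known; the expected step is a number 25 percentage points higher from compound 1 to compound 3 (beyond the scatter). For compound 3 the estimated value in this assay is 70%, within a range from 45% to 92%.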

Compound 3, percent of the compound remaining: 69%
Compound 3: middle estimate off by 1 percentage points, on the high side; low and high end bracket the measured number.
By their numbers in this assay, from the lowest: compound 1; then compound 3; then compound 2.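

In this assay, a second replacement for pyridin-2-yl on a nitrogen on an aromatic ring also raises the number, with a number 24 percentage points higher from compound 1 to compound 3 (beyond the scatter) as the step, so among these three compounds pyridin-2-yl gives the lowest number and neither replacement goes against that. The two replacement rings are not interchangeable, however: the step of a number 19 percentage points lower from compound 2 to compound 3 (beyond the scatter) shows that the result depends on which ring enters, and not only on pyridin-2-yl leaving. No available evidence explains this difference between pyridazin-3-yl and pyrimidin-4-yl.

The compounds shown leave open how a pyrazin-2-yl ring would behave at this place, and whether a methyl or methoxy group on the pyridazin-3-yl ring would change the number in this assay in either direction. Going by these compounds, they also cover a single shared core and a single species of liver microsomes, so whether the same order of the three rings would hold on another core or in another species remains unknown.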